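The source may report more compounds than this note shows. Statements on the series, on what has been measured and on what is new or still open speak of the compounds shown alone.

Within the data shown here, in a functional assay on A549 cells (Homo sapiens) for cytotoxicity, read by MTT assay, with a stated time of 48 h (on this read-out higher numbers stand for weaker inhibition and lower numbers for stronger inhibition), compound 1 `O=C(/C=C\Nc1ccc2cc[nH]c2c1)c1c(-c2ccc(Cl)cc2)nc2ccccn12` gives 2290 nM and compound 2 `O=C(/C=C\Nc1cnc2ccccc2c1)c1c(-c2ccc(Cl)cc2)nc2ccccn12` gives 2880 nM, so compound 2 stands level with the only other measured compound, within the scatter. Compound 3 `O=C(/C=C\Nc1ccc2ncccc2c1)c1c(-c2ccc(Cl)cc2)nc2ccccn12` keeps the shared core and differs from compound 2 in one place: quinolin-6-yl in place of quinolin-3-yl on an amine nitrogen. Among the measured compounds shown here, the one measured step that bears on this swaps the group at that same nitrogen, a 1.3-fold higher number from compound 1 to compound 2 (0.10 log units; within the scatter), so no change beyond the scatter is expected here. The estimated move is a 1.1-fold lower number from compound 2 to compound 3 (0.04 log units; within the scatter). For compound 3 the expected value is 2600 nM, with an estimated range of 1200 nM to 5500 nM.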

Compound 3, half-maximal inhibitory concentration: 13000 nM
For compound 3 the middle estimate is 5.0-fold (0.70 log units) below the measured one, and the stated range ends below it.
By their numbers in this assay, from the lowest: compounds 1 and 2 (each within the scatter of the next); then compound 3.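

At the amine nitrogen, the point where the quinoline group attaches matters: in this assay, quinolin-6-yl in place of quinolin-3-yl gives a 4.5-fold higher number from compound 2 to compound 3 (0.65 log units; beyond the scatter), although the two groups have the same atoms. Replacing 1H-indol-6-yl with quinolin-6-yl likewise weakens inhibition, with a 5.7-fold higher number from compound 1 to compound 3 (0.75 log units; beyond the scatter). No evidence at hand explains this loss. Still open, as far as these compounds go, is whether quinolin-5-yl or quinolin-7-yl on that nitrogen would side with quinolin-3-yl or with quinolin-6-yl. A plain phenyl group there would show how much the second ring contributes.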